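This account rests on a few compounds, and the source may have more. Where it says the series, first, only, none or still open, it means among the compounds named here.

Three compounds share one core and differ only in the aryl group carried on a nitrogen on an aromatic ring. In a functional assay on A549 cells (Homo sapiens) for antiproliferative activity, read by MTT assay, with a stated time of 72 h (on this read-out lower numbers stand for stronger inhibition and higher numbers for weaker inhibition), compound 1 `COc1cc2ncnc(Nc3ccc(Cl)c(C(F)(F)F)c3)c2cc1OCCCCC(=O)Nc1ccc(S(N)(=O)=O)cc1` gives 9270 nM, compound 2 `COc1cc2ncnc(Nc3ccc(F)c(Br)c3)c2cc1OCCCCC(=O)Nc1ccc(S(N)(=O)=O)cc1` gives 16000 nM, and compound 3 `COc1cc2ncnc(Nc3cccc(C)c3)c2cc1OCCCCC(=O)Nc1ccc(S(N)(=O)=O)cc1` gives 16000 nM. Compound 3 stands level with compound 2, the two together the highest of the three numbers, and the furthest step within the set is a 1.7-fold higher number from compound 1 to compound 3 (0.24 log units; within the scatter). Compound 4 `COc1ccccc1Nc1ncnc2cc(OC)c(OCCCCC(=O)Nc3ccc(S(N)(=O)=O)cc3)cc12` is reached from compound 3 by 2-methoxyphenyl in place of 3-methylphenyl on a nitrogen on an aromatic ring. Going by the values given here, no measured step brings in a 2-methoxyphenyl, but every change of this aryl group so far stayed within the scatter: a 1.7-fold higher number from compound 1 to compound 2 (0.24 log units; within the scatter), a 1.7-fold higher number from compound 1 to compound 3 (0.24 log units; within the scatter) and no change at the digits printed from compound 2 to compound 3 (within the scatter). The expected step is therefore no change at the digits printed from compound 3 to compound 4 (within the scatter). Compound 4 is estimated at 16000 nM, between 6000 nM and 40000 nM.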

Compound 4, half-maximal inhibitory concentration: 24100 nM
Compound 4: the middle estimate sits 1.5-fold (0.18 log units) below what was measured; measured number inside the range.
By their numbers in this assay, from the lowest: compounds 1, 2, 3 and 4 (each within the scatter of the next, the first and the last beyond it).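

In this assay, going by these compounds alone, 2-methoxyphenyl is the first aryl group here to bring an oxygen onto this nitrogen, and it stays within the scatter of 3-methylphenyl and of 3-bromo-4-fluorophenyl, with a 1.5-fold higher number from compound 3 to compound 4 (0.18 log units; within the scatter) and a 1.5-fold higher number from compound 2 to compound 4 (0.18 log units; within the scatter). Against 4-chloro-3-(trifluoromethyl)phenyl, however, the set shows its first step at this position beyond the scatter, though still a modest one: a 2.6-fold higher number from compound 1 to compound 4 (0.41 log units; beyond the scatter). No evidence is available to explain this difference. The compounds shown leave open whether an aryl group carrying an amine or a carboxylic acid would shift the number further.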